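Fluoro for methoxy: expectation for compound 3

The source may hold more compounds than are shown below. What is called first, only, known or untested is meant among the compounds shown, and "the series" means these compounds.

Measured compounds:
- compound 1: `Cc1ccc(/C=C2\CCC/C(=C\c3ccccc3[N+](=O)[O-])C2=O)cc1` — 7520 nM
- compound 2: `COc1ccc(/C=C2\CCC/C(=C\c3ccccc3[N+](=O)[O-])C2=O)cc1` — 8900 nM

In a functional assay on MOLT-4 cells (Homo sapiens) for cytotoxicity, with a stated time of 72 h (a lower number here means a stronger inhibitor, a higher number a weaker inhibitor), compound 1 gives 7520 nM. In this assay compound 2 gives 8900 nM. Going by the values given here, the one step between them, a 1.2-fold higher number from compound 1 to compound 2 (0.07 log units; within the scatter), puts the two numbers within the scatter of each other, so compound 2 cannot be told apart from compound 1 on these data; it is the one of the two with the nominally higher number, and compound 1 is its only neighbour.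

The next compound, compound 3 `O=C1/C(=C/c2ccc(F)cc2)CCC/C1=C\c1ccccc1[N+](=O)[O-]`, differs from compound 2 at the same position that distinguishes compound 1 from compound 2: fluoro in place of methoxy on an aromatic carbon. Among the compounds with values here, the only measured step that bears on this position is a 1.2-fold higher number from compound 1 to compound 2 (0.07 log units; within the scatter), a swap of one small group for another that stayed within the scatter. Within the data shown here, no measured step involves fluoro, and nothing here separates the two measured groups at this position.

The step from compound 2 to compound 3 is therefore expected to be small, a 1.1-fold lower number from compound 2 to compound 3 (0.05 log units; within the scatter), with no direction claimed beyond the scatter. For compound 3 in this assay the estimate is 8000 nM, within a range of 3000 nM to 20000 nM.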

Compound 3, half-maximal inhibitory concentration: 1870 nM
The estimate for compound 3 lay 4.3-fold (0.63 log units) above the measured number; measured number outside the range, below it.
By their numbers in this assay, from the lowest: compound 3; then compounds 1 and 2 (each within the scatter of the next).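

Within this assay the group on this aromatic carbon now matters: a 4.8-fold lower number from compound 2 to compound 3 (0.68 log units; beyond the scatter) is a modest step beyond the scatter, and a 4.0-fold lower number from compound 1 to compound 3 (0.60 log units; beyond the scatter) is one of similar standing, so fluoro separates from both groups measured earlier. The only earlier comparison, a 1.2-fold higher number from compound 1 to compound 2 (0.07 log units; within the scatter), could not tell methoxy from methyl and gave no sign that this place could move the number at all; with compound 3 the place is shown to respond, and fluoro gives the lower number against each of the other two groups. Nothing at hand accounts for why fluoro parts from methoxy and methyl here.

The series leaves open whether this lower number belongs to fluoro alone or would also appear with chloro, bromo, trifluoromethyl or nitrile on the same carbon, and whether a hydroxyl or an amine there would fall with fluoro or with methoxy and methyl. Going by these compounds, the nitro group on the other aromatic ring stays constant across all three compounds, so it also remains open whether the fluoro step would hold with an amine or a nitrile in its place.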